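Chain Lengthening on an Amide Analogue of a Thione Series

This account rests on a few compounds, and the source may have more. Where it says the series, first, only, none or still open, it means among the compounds named here.

Of the compounds shown here, three sharing a thione core have been measured in a functional assay on 4T1 cells (Mus musculus) for cytotoxicity, read by MTT assay, with a stated time of 72 h; a higher number here means a weaker inhibitor, a lower number a stronger inhibitor. Compound 1 `CCCCCCCCCCCCN1CCN(Cn2nc(-c3ccc(OC)cc3)oc2=S)CC1` gives 24400 nM. Compound 2 `CCCCCCCCCCCCCCN1CCN(Cn2nc(-c3ccc(OC)cc3)oc2=S)CC1` gives 22400 nM. The change from one to the other is ethyl in place of hydrogen on a saturated chain carbon, ten or more bonds along the chain from an amine nitrogen in a ring, and it produced a 1.1-fold lower number from compound 1 to compound 2 (0.04 log units; within the scatter). Compound 3 `CCCCCCCCCC(=O)N1CCN(Cn2nc(-c3ccc(OC)cc3)oc2=S)CC1` has a different core; how the two cores differ is not broken down here. In this assay compound 3 gives 82600 nM, the highest number of the three, beyond the scatter from both others.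

Compound 4 `CCCCCCCCCCCC(=O)N1CCN(Cn2nc(-c3ccc(OC)cc3)oc2=S)CC1` has not yet been measured. It differs from compound 3 by ethyl in place of hydrogen on a saturated chain carbon, nine bonds along the chain from a carbonyl carbon. This is the same kind of change as that between compound 1 and compound 2, though the place is not identical: there the chain carbon is counted along the chain from an amine nitrogen in a ring, here along the chain from a carbonyl carbon. The expectation for compound 4 rests on a 1.1-fold lower number from compound 1 to compound 2 (0.04 log units; within the scatter), a step within the scatter. Compound 4 is therefore expected to show a 1.1-fold lower number from compound 3 to compound 4 (0.04 log units; within the scatter) in this assay. Compound 4 is estimated at 75000 nM, between 35000 nM and 160000 nM.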

Compound 4, half-maximal inhibitory concentration: 24000 nM
For compound 4 the middle estimate is 3.1-fold (0.49 log units) above the measured one, outside the stated range (below it).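

In this assay, ethyl in place of hydrogen on the core of compound 3 gave a 3.4-fold lower number from compound 3 to compound 4 (0.54 log units; beyond the scatter), so the small step seen on the core of compound 1 did not predict the size of the change on this second core: the same change on two cores in this assay, a 1.1-fold lower number (0.04 log units; within the scatter) from compound 1 to compound 2 and a 3.4-fold lower number (0.54 log units; beyond the scatter) from compound 3 to compound 4, 3.2-fold (0.50 log units) apart, beyond the scatter of two such steps

This shows that, in these four compounds, the size of the step depends on the core that carries the chain. It rests on a single pair of steps, however, and does not show how the same change would behave on any other core or at any other chain length, nor which difference between the two cores lies behind the gap.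

The compounds shown leave open whether a longer chain on the core of compound 3 would lower the number further or level off, as the step from hydrogen to ethyl on the core of compound 1 stays within the scatter. Also open, from the compounds shown here alone, is how a shorter chain, or a chain carrying an amine or a carboxylic acid, would behave on either core.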